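Thiazole amide series: methyl in place of trifluoromethyl

The compounds below may be only part of what the source reports. "The series", "measured", "known", "first", "only" and "open" are said of these compounds alone.

Measured in a functional assay for antagonist activity at thyroid hormone receptor alpha (Homo sapiens), read by fluorescence polarization; a higher number here means a weaker inhibitor, a lower number a stronger inhibitor:
compound 1, `CC1(C)CC2CC(C)(CN2C(=O)c2sc(-c3ccc(S(C)(=O)=O)c([N+](=O)[O-])c3)nc2C(F)(F)F)C1`, gives 430 nM
compound 2, `CC1CCN(C(=O)c2sc(-c3ccc(S(C)(=O)=O)c([N+](=O)[O-])c3)nc2C(F)(F)F)CC1`, gives 190 nM
compound 3, `CN(Cc1ccccc1)C(=O)c1sc(-c2ccc(S(C)(=O)=O)c([N+](=O)[O-])c2)nc1C(F)(F)F`, gives 460 nM

Compound 1 stands second highest of the three numbers in this assay. Its nearest neighbour is compound 3, a 1.1-fold higher number from compound 1 to compound 3 (0.03 log units; within the scatter), which is within the scatter. The furthest is compound 2, a 2.3-fold lower number from compound 1 to compound 2 (0.35 log units; beyond the scatter), a modest step. The remaining pair also differs: a 2.4-fold higher number from compound 2 to compound 3 (0.38 log units; beyond the scatter). All three measured steps change the group on the carbonyl carbon and leave the shared core untouched.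

Compound 4, `Cc1nc(-c2ccc(S(C)(=O)=O)c([N+](=O)[O-])c2)sc1C(=O)N1CC2(C)CC1CC(C)(C)C2`, is not yet measured. It differs from compound 1 in one place: methyl in place of trifluoromethyl on an aromatic carbon. Going by the values given here, none of the measured steps touches this position of the core, so no measured step bears on this change. The data give no basis for a direction. The expectation is therefore a step in this assay that stays within the scatter, with a wide range around it to reflect the absence of any comparable step. For compound 4 the estimated value in this assay is 500 nM, with a range from 150 nM to 1800 nM, meaning an expected step of a 1.2-fold higher number from compound 1 to compound 4 (0.07 log units; within the scatter).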

Compound 4, half-maximal inhibitory concentration: 3500 nM
Estimate against measurement, compound 4: 7.0-fold (0.85 log units) below; the whole stated range lies below it.
By their numbers in this assay, from the lowest: compound 2; then compounds 1 and 3 (each within the scatter of the next); then compound 4.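

The position on the aromatic carbon next to the ring nitrogen is not neutral in this assay: methyl in place of trifluoromethyl gives an 8.1-fold higher number from compound 1 to compound 4 (0.91 log units; beyond the scatter) and leaves the group on the carbonyl carbon unchanged. This step is larger than any of the steps among compounds 1, 2 and 3, all of which change the group on the carbonyl carbon, so among the changes shown, this one on the shared core moves the number furthest. What lies behind the step cannot be told, as nothing available here bears on its cause.

Open, as far as these compounds go, is where ethyl, chlorine, cyclopropyl or a plain hydrogen at this position would fall relative to the trifluoromethyl and methyl pair in this assay. Going by these compounds alone, also open is whether the same exchange gives a step of similar size with the 4-methylpiperidin-1-yl group of compound 2 or the benzyl(methyl)amino group of compound 3 on the carbonyl carbon, as the only pair available for this change carries the bicyclic amine group of compound 1.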